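A few compounds are considered here, and "the series" means these few. Any claim that something is new, unique, unknown or untested is made for them only; others in the source may bear on it.

Compound 1 `COC(=O)CC1c2ccc(Cl)cc2NC(=O)C1S(C)(=O)=O` and compound 2 `COC(=O)CC1c2ccc(Cl)cc2NC(=O)C1C(=O)c1ccccc1` share one core and differ only in the group on a saturated ring carbon. Both have been tested in a physicochemical assay for acid dissociation. Compound 1 gives > 11, which is a limit of the assay and not a number. Among the measured compounds shown here, compound 2 gives about 9, the only actual number so far.

Compound 3 `COC(=O)CC1c2ccc(Cl)cc2NC(=O)C1C#N` keeps the core of compound 2 and changes the group at that same place: cyano in place of benzoyl on a saturated ring carbon. For the measured compounds named here, the single measured step at this place, benzoyl in place of methylsulfonyl, is a number at least 2.00 log units lower from compound 1 to compound 2 (beyond the scatter), and it suggests that losing benzoyl may raise the number again. Going by the values given here, this is thin support, since it is one step and no measured compound carries cyano yet. A rise of part of that size is therefore expected in this assay, estimated as a number 1.50 log units higher from compound 2 to compound 3 (beyond the scatter). For compound 3 the expected value is 10.5, with an estimated range from 9.5 to 11.5.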

Compound 3, acid dissociation constant: 10.2
Compound 3: the middle estimate sits 0.30 log units above what was measured, and the stated range covers the measured number.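

In this assay, the group on this saturated ring carbon now has three readings on one shared core, and swapping it alone moves the number: cyano in place of benzoyl gives a number 1.20 log units higher from compound 2 to compound 3 (beyond the scatter). Cyano in place of methylsulfonyl gives a number at least 0.80 log units lower from compound 1 to compound 3 (beyond the scatter), so the three groups fall into an order, with benzoyl giving the lowest number, then cyano, then methylsulfonyl. Compound 1 gives > 11, which is a limit of the assay and not a number.

How far methylsulfonyl really lies from cyano in this assay stays unknown, since only a one-sided size can be given for that step: the limit of > 11 in this assay, at which 1 of the 3 values shown sits. The compounds shown also cannot say what sets the order, since benzoyl differs from cyano in several ways at once, including its six-membered aromatic ring and its carbonyl, and a group such as acetyl, which has a carbonyl but no ring, or an amine or a carboxylic acid at this same place, would be needed to pull those features apart.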